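Swapping a triazolyl chain end for allyl on the shared core

This account rests on a few compounds, and the source may have more. Where it says the series, first, only, none or still open, it means among the compounds named here.

compound 1 `Cn1ncc(Cl)c1-c1cc(C(=O)N[C@@H]2CN[C@H](CCCO)C[C@H]2c2ccc(Cl)c(Cl)c2)oc1Cl` gives 510 nM
compound 2 `Cn1ncc(Cl)c1-c1cc(C(=O)N[C@@H]2CN[C@H](CCn3cncn3)C[C@H]2c2ccc(Cl)c(Cl)c2)oc1Cl` gives 560 nM
compound 3 `Cn1ncc(Cl)c1-c1cc(C(=O)N[C@@H]2CN[C@H](CCO)C[C@H]2c2ccc(F)c(F)c2)oc1Cl` gives 360 nM

In a functional assay on HCT-116 cells (Homo sapiens) for antiproliferative activity, read by sulforhodamine B assay, with a stated time of 72 h (on this read-out lower numbers stand for stronger inhibition and higher numbers for weaker inhibition), compound 2 gives 560 nM and sits within the usual scatter of the other two compounds, so the three numbers cannot be ranked. Among the measured compounds shown here, compound 3 differs from the others in more than one place and offers no clean step. Compound 4 `C=CC[C@@H]1C[C@@H](c2ccc(Cl)c(Cl)c2)[C@H](NC(=O)c2cc(-c3c(Cl)cnn3C)c(Cl)o2)CN1` has not yet been measured. It carries vinyl in place of (1H-1,2,4-triazol-1-yl)methyl on a saturated chain carbon bound to a saturated ring carbon in all. Read one bond further out, this is 2-(1H-1,2,4-triazol-1-yl)ethyl to allyl. For the measured compounds named here, one measured step bears on it: a 1.1-fold higher number from compound 1 to compound 2 (0.04 log units; within the scatter) for 1H-1,2,4-triazol-1-yl in place of hydroxymethyl on that chain. Going by the values given here, that step stayed within the scatter, but no measured compound carries a vinyl group, so the guide is thin. No shift beyond the scatter is expected in either direction, and the estimated step is a 1.2-fold lower number from compound 2 to compound 4 (0.09 log units; within the scatter) in this assay as the working expectation. For compound 4 the estimate is 450 nM with an expected range of 200 nM to 1000 nM.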

Compound 4, half-maximal inhibitory concentration: 780 nM
Beside the measured number, compound 4's estimate is 1.7-fold (0.24 log units) below it, and the stated range covers the measured number.
By their numbers in this assay, from the lowest: compounds 3, 1, 2 and 4 (each within the scatter of the next, the first and the last beyond it).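

In this assay the change on a saturated chain carbon bound to a saturated ring carbon can now be read for a chain end made only of carbon: vinyl in place of (1H-1,2,4-triazol-1-yl)methyl (a 1.4-fold higher number from compound 2 to compound 4 (0.14 log units; within the scatter)) and vinyl in place of 2-hydroxyethyl (a 1.5-fold higher number from compound 1 to compound 4 (0.18 log units; within the scatter)). Vinyl has no ring and 0 hydrogen-bond acceptors, yet both steps stay within the scatter, so among compounds 1, 2 and 4 neither the triazole ring nor the hydroxyl shows a measurable contribution at this position. No other measurement is available to explain this result.

Still open, as far as these compounds go, is how a chain ending in an amine or a carboxylic acid would read at this position. A saturated propyl chain would also show whether the double bond of allyl makes any difference.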